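Changing the amide aryl of compound 2 toward compound 4

The compounds below may be only part of what the source reports. "The series", "measured", "known", "first", "only" and "open" are said of these compounds alone.

In a functional assay on HEK293 cells for agonist activity at probable G-protein coupled receptor 27 (Homo sapiens), read by a luciferase reporter and beta-arrestin recruitment, with a stated time of 10 min (a higher number here means that more compound is needed for the effect, a lower number that less compound is needed), three compounds of a shared core have been measured. Compound 1 `O=C(Nc1ccc(S(=O)(=O)Nc2ccc(Cl)cc2)cc1)c1ccc(Cl)cc1Cl` reaches only a limit of the assay, > 100000 nM. Compound 3 `Cc1ccccc1NS(=O)(=O)c1ccc(NC(=O)c2ccc(Cl)cc2Cl)cc1` gives 1230 nM. Going by the values given here, the one measured step, an at least 81-fold lower number from compound 1 to compound 3 (1.91 log units; beyond the scatter), is the only comparison available, and it concerns the sulfonamide nitrogen; the record notes (the limit of > 100000 nM in this assay, at which 1 of the 3 values shown sits). Compound 2 `O=C(Nc1ccc(S(=O)(=O)Nc2ccccc2)cc1)c1ccc(Cl)nc1F` gives 2290 nM, which is the highest of the two numbers, while its distance to compound 3 lies within the scatter, so no order between them can be claimed.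

Compound 4 `O=C(Nc1ccc(S(=O)(=O)Nc2ccccc2)cc1)c1ccc(I)cc1F` differs from compound 2 on the carbonyl side: 2-fluoro-4-iodophenyl in place of 6-chloro-2-fluoropyridin-3-yl on a carbonyl carbon. Among the compounds with values here, no measured step touches this position, so the size of the step from compound 2 to compound 4 is not anchored by data. The two measured compounds that carry a dichlorophenyl on the carbonyl, compound 1 and compound 3, sit far apart, and that spread comes from the sulfonamide side. In the absence of a bearing step, the step from compound 2 to compound 4 is expected to stay within the scatter, a 1.4-fold lower number from compound 2 to compound 4 (0.16 log units; within the scatter). Compound 4 is therefore estimated at 1600 nM, within a range from 300 nM to 9000 nM.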

Compound 4, half-maximal effective concentration: 5130 nM
Estimate against measurement, compound 4: 3.2-fold (0.51 log units) below; the range from low to high includes it.
By their numbers in this assay, from the lowest: compounds 3 and 2 (each within the scatter of the next); then compound 4. At a limit, above all of these: compound 1.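

In this assay, the carbonyl side of the shared core now has its first measured step: a 2.2-fold higher number from compound 2 to compound 4 (0.35 log units; beyond the scatter). Going by these compounds alone, every earlier comparison concerned the sulfonamide nitrogen, so this is the first sign that the aryl group on a carbonyl carbon whose other neighbour is an amide-type nitrogen can move the number beyond the scatter, with the phenyl on the sulfonamide nitrogen held the same in both compounds. Nothing measured here bears on why this replacement gives a step of this size.

The compounds shown leave open whether the step follows from the loss of the ring nitrogen or from the exchange of chlorine for iodine, since the one replacement brings both changes together. They also leave open how an amine or a carboxylic acid in place of the iodine of the 2-fluoro-4-iodophenyl would read, and whether this carbonyl-side change would give a step of similar size with the 2-methylphenyl on the sulfonamide nitrogen, as carried by compound 3.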